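The source may report more compounds than this note shows. Statements on the series, on what has been measured and on what is new or still open speak of the compounds shown alone.

Compound 3 `C=C(Br)C(=O)Nc1cccc(-c2cn3nc(-c4ccccc4)sc3n2)c1` gives 1400 nM in a functional assay on HeLa cells (Homo sapiens) for inhibition, read by cell counting, with a stated time of 4 days (on this read-out higher numbers stand for weaker inhibition and lower numbers for stronger inhibition), the lowest of the three numbers recorded there. Compound 1 `CCc1ccc(-c2nn3cc(-c4cccc(N)c4)nc3s2)cc1` gives 8100 nM in this assay, and compound 2 `CCOc1ccc(-c2nn3cc(-c4cccc(N)c4)nc3s2)cc1` gives 94000 nM. The single one-place step among these, a 12-fold higher number from compound 1 to compound 2 (1.06 log units; beyond the scatter), shows that an oxygen-linked group on the pendant phenyl of the shared core went with a clearly weaker result. Compound 4 `C=C(Br)C(=O)Nc1cccc(-c2cn3nc(-c4ccc(OC)c(OC)c4)sc3n2)c1` differs from compound 3 by 3,4-dimethoxyphenyl in place of phenyl on an aromatic carbon. Compound 4 thus carries two methoxy groups on the phenyl that sits on the five-membered ring of the shared core, while compound 3 has that phenyl bare. Among the compounds with values here, the only step that bears on this, the one from compound 1 to compound 2, was large and toward weaker inhibition, though its setting differs, since there the change was on the other pendant phenyl and compound 3 lacks the amine of compound 1. For compound 4 a moderate step toward a higher number is therefore expected, a 2.9-fold higher number from compound 3 to compound 4 (0.46 log units; beyond the scatter), giving an estimated 4000 nM with a range from 1000 nM to 16000 nM.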

Compound 4, half-maximal inhibitory concentration: 610 nM
Compound 4: the middle estimate sits 6.6-fold (0.82 log units) above what was measured; measured number below the stated range.
By their numbers in this assay, from the lowest: compound 4; then compound 3; then compound 1; then compound 2.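

In this assay, 3,4-dimethoxyphenyl in place of phenyl on the aromatic carbon of the five-membered ring gave a 2.3-fold lower number from compound 3 to compound 4 (0.36 log units; beyond the scatter) and so the larger group was accepted at this position without loss, the step being modest but beyond the scatter. Its direction is opposite to that of a 12-fold higher number from compound 1 to compound 2 (1.06 log units; beyond the scatter) and so the earlier oxygen-linked change, made on a different core position and with a free amine present, does not carry over to this setting. No measurement shown here accounts for the step.

The compounds shown leave open whether a single methoxy group would give the same result, or how a hydroxyl, an amine or a carboxylic acid on this phenyl would fare. They also leave open whether the step would hold with the free amine of compound 1 in place of the bromoacrylamide.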